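This account rests on a few compounds, and the source may have more. Where it says the series, first, only, none or still open, it means among the compounds named here.

Compound 1 `COc1cc(-c2ccnc3cc(-c4ccc(F)cc4)nn23)cc(OC)c1OC`: 5030 nM
Compound 2 `COc1cc(-c2ccnc3cc(-c4ccc(Cl)cc4)nn23)cc(OC)c1OC`: 3340 nM
Compound 3 `COc1cc(-c2ccnc3cc(-c4cccc(C#N)c4)nn23)cc(OC)c1OC`: > 10000 nM

All three compounds were tested in a functional assay on HCT-116 cells (Homo sapiens) for inhibition, read by CCK-8 assay, with a stated time of 48 h; on this read-out lower numbers stand for stronger inhibition and higher numbers for weaker inhibition. Compound 3 gives only a limit of the assay, > 10000 nM, and not a number. The next compound, compound 4 `COc1cc(-c2ccnc3cc(-c4ccccc4)nn23)cc(OC)c1OC`, has not yet been measured. It differs from compound 3 by hydrogen in place of cyano on an aromatic carbon, which is hydrogen in place of cyano on an aromatic carbon, so that 3-cyanophenyl becomes phenyl.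

Among the compounds with values here, two measured steps bear on this change, since both go from a halogen-bearing phenyl to 3-cyanophenyl: an at least 1.9-fold higher number from compound 1 to compound 3 (0.29 log units; that floor lies within the scatter) and an at least 2.9-fold higher number from compound 2 to compound 3 (0.47 log units; beyond the scatter). The third, a 1.5-fold lower number from compound 1 to compound 2 (0.18 log units; within the scatter), shows that the two halogens are not separated in this assay. Within the data shown here, no measured compound carries the bare phenyl, so the comparison is indirect. Compound 1, at 5030 nM, and compound 2, at 3340 nM, both give real numbers without the cyano group, so a move back toward them is expected, in the direction of a lower number. The expected change is an at least 1.6-fold lower number from compound 3 to compound 4 (0.22 log units; that floor lies within the scatter), and it may not clear the scatter, as the limit hides the true starting point. For compound 4 the estimate is 6000 nM, with an expected range from 2500 nM to 14000 nM.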

Compound 4, half-maximal inhibitory concentration: 3880 nM
For compound 4 the middle estimate is 1.5-fold (0.19 log units) above the measured one, within the range that was stated.
By their numbers in this assay, from the lowest: compounds 2, 4 and 1 (each within the scatter of the next). At a limit, above all of these: compound 3.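

In this assay, within the data shown here, hydrogen in place of cyano gives an at least 2.5-fold lower number from compound 3 to compound 4 (0.41 log units; beyond the scatter), the first direct reading of this change at this position, and even this floor lies beyond the scatter. Compound 3 gives only a limit of the assay and not a number, so the full size of the step stays hidden: the limit of > 10000 nM in this assay, at which 1 of the 4 values shown sits. The bare phenyl of compound 4 also joins the halogen-bearing compounds, with a 1.2-fold higher number from compound 2 to compound 4 (0.07 log units; within the scatter) and a 1.3-fold lower number from compound 1 to compound 4 (0.11 log units; within the scatter), so among these four compounds neither chloro nor fluoro is separated from hydrogen, and only the 3-cyanophenyl compound stands apart.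

The compounds shown carry cyano only in 3-cyanophenyl and the halogens only in 4-fluorophenyl and 4-chlorophenyl, so the effect of the group cannot be told apart from that of its place on the ring. From the compounds shown here alone, how an amine, a carboxylic acid or a longer chain on this ring would read in this assay also stays open.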